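The compounds below may be only part of what the source reports. "The series", "measured", "known", "first", "only" and "open" are said of these compounds alone.

Compound 1 `Nc1sc(-c2ccc(Cl)cc2)c(-c2ccc(Cl)cc2)c1C(=O)N1CCCCC1=O` gives 1820 nM in a functional assay on A549 cells (Homo sapiens) for inhibition, read by sulforhodamine B assay, with a stated time of 72 h; a lower number here means a stronger inhibitor, a higher number a weaker inhibitor.
Compound 2 `Nc1sc(-c2ccc(Cl)cc2)c(-c2ccc(Cl)cc2)c1C(=O)NC1CCCCC1` gives 2410 nM in this assay.
Compound 3 `Nc1sc(-c2ccc(Cl)cc2)c(-c2ccc(Cl)cc2)c1C(=O)Nc1ccccc1` gives 25000 nM in this assay.

Compound 2 stands second highest of the three numbers. Its nearest neighbour is compound 1, which differs only within the scatter (a 1.3-fold higher number from compound 1 to compound 2 (0.12 log units; within the scatter)), while compound 3 lies far away (a 10-fold higher number from compound 2 to compound 3 (1.02 log units; beyond the scatter)). Compound 4 `CN1CCN(C(=O)c2c(N)sc(-c3ccc(Cl)cc3)c2-c2ccc(Cl)cc2)CC1` has not yet been measured. It differs from compound 2 by 4-methylpiperazin-1-yl in place of cyclohexylamino on a carbonyl carbon. Going by the values given here, two measured steps bear on this change. Compound 1, like compound 4, carries a group with no hydrogen-bond donor on the carbonyl carbon, and it sits within the scatter of compound 2 (a 1.3-fold higher number from compound 1 to compound 2 (0.12 log units; within the scatter)), so removing the donor alone has not moved the number among these compounds. The large change came with a phenyl group (a 10-fold higher number from compound 2 to compound 3 (1.02 log units; beyond the scatter)), which compound 4 does not carry. No step beyond the scatter is therefore expected in this assay. Compound 4 is estimated at 2500 nM, within 800 nM to 8000 nM, which is expected to mean a step of a 1.0-fold higher number from compound 2 to compound 4 (0.02 log units; within the scatter).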

Compound 4, half-maximal inhibitory concentration: 590 nM
Estimate against measurement, compound 4: 4.2-fold (0.63 log units) above; the whole stated range lies above it.
By their numbers in this assay, from the lowest: compound 4; then compounds 1 and 2 (each within the scatter of the next); then compound 3.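

The group on this carbonyl carbon can lower the number as well as raise it in this assay: 4-methylpiperazin-1-yl gives a 4.1-fold lower number from compound 2 to compound 4 (0.61 log units; beyond the scatter) and a 3.1-fold lower number from compound 1 to compound 4 (0.49 log units; beyond the scatter), making compound 4 the strongest inhibitor of the four. Going by these compounds alone, until now, the only steps beyond the scatter at this position had gone upward, and the new group widens the range to a 42-fold lower number from compound 3 to compound 4 (1.63 log units; beyond the scatter). Cyclohexylamino and 4-methylpiperazin-1-yl are both six-membered non-aromatic rings with the same heavy-atom count, so that shared ring size and count do not fix the number here.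

No measurement shown explains why the number falls with this change. Going by these compounds, the role of the methyl group and of the second ring nitrogen remains open, and piperazin-1-yl, 4-ethylpiperazin-1-yl and morpholin-4-yl at this position would each test part of that question.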